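Trifluoromethyl for Chloro on a Pair at the Limit

The source may hold more compounds than are shown below. What is called first, only, known or untested is meant among the compounds shown, and "the series" means these compounds.

compound 1, `Cc1cc(Nc2cccc(Cl)c2)nc(N)n1`: > 180000 nM
compound 2, `Cc1cc(Nc2cc(Cl)ccc2Cl)nc(N)n1`: > 180000 nM

In an assay on cells for inhibition of S-adenosylmethionine decarboxylase proenzyme (Homo sapiens), read by mass spectrometry, at pH 7.2 (a lower number here means a stronger inhibitor, a higher number a weaker inhibitor), compound 1 gives > 180000 nM, which is a limit of the assay and not a number. Compound 2 also gives only a limit, > 180000 nM. The step that the two limits leave unreadable from compound 1 to compound 2 cannot be read, because both of its ends sit at the limit of > 180000 nM in this assay, at which 2 of the 2 values shown sit. Compound 2 therefore stands at the limit of this assay, with no number of its own to compare against.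

Compound 3, `Cc1cc(Nc2cc(C(F)(F)F)ccc2Cl)nc(N)n1`, differs from compound 2 by trifluoromethyl in place of chloro on an aromatic carbon. Within the data shown here, the one measured step, from compound 1 to compound 2, is unreadable, so no measured step sets a size or a direction for this change. With both known values at the limit, compound 3 is expected to stay at or near it, and the expected step that the limit leaves unreadable from compound 2 to compound 3 is not beyond the scatter. The estimate for compound 3 in this assay is 200000 nM, with a range from 40000 nM to 1000000 nM.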

Compound 3, half-maximal inhibitory concentration: > 180000 nM
Compound 3: only a limit was reported; the forecaster's own chance of this, stated with the estimate: 85%; the middle value is on the limit's open side.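

Among these compounds, no step from compound 2 to compound 3 can be read, because both values are limits of the assay and not numbers: the limit of > 180000 nM in this assay, at which 3 of the 3 values shown sit. The compounds shown leave open how strongly any of them acts in this assay, and whether trifluoromethyl in place of chloro changes that at all.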